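The source may hold more compounds than are shown below. What is called first, only, known or untested is meant among the compounds shown, and "the series" means these compounds.

Measured compounds:
- compound 1, `C=CCn1c(=O)c2[nH]cnc2n(CCC)c1=O`: in a functional assay (trachea) with Cavia porcellus as the target (a lower number here means that less compound is needed, a higher number that more compound is needed for the effect), compound 1 gives 1600 nM
- compound 2, `CCCn1c(=O)n(CCC(C)=O)c(=O)c2[nH]cnc21`: in this assay compound 2 gives 3500 nM

Among the compounds with values here, compound 1 stands lowest of the two numbers; the only other measured compound, compound 2, lies beyond the scatter from it: a 2.2-fold higher number from compound 1 to compound 2 (0.34 log units; beyond the scatter).

Compound 3, `CCCn1c(=O)n(CCCCC(C)=O)c(=O)c2[nH]cnc21`, has not yet been measured in this assay. It differs from compound 1 as follows: 3-acetylpropyl in place of vinyl on a saturated chain carbon bound to an aromatic nitrogen. Within the data shown here, the one measured step that bears on this change is the move from compound 1 to compound 2, where a shorter ketone chain replaced the same vinyl group at the same place and produced a 2.2-fold higher number from compound 1 to compound 2 (0.34 log units; beyond the scatter). The lengthened ketone chain in compound 3 is therefore expected to give a modest rise in the number again, of about a 2.0-fold higher number from compound 1 to compound 3 (0.30 log units; within the scatter). Compound 3 is thus estimated to give 3200 nM in this assay, with a range from 1300 nM to 8000 nM.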

Compound 3, half-maximal effective concentration: 60 nM
For compound 3 the middle estimate is 53-fold (1.73 log units) above the measured one; measured number outside the range, below it.
By their numbers in this assay, from the lowest: compound 3; then compound 1; then compound 2.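

In this assay the chain at this position matters far more than the earlier pair showed: there is a 27-fold lower number from compound 1 to compound 3 (1.43 log units; beyond the scatter) when 3-acetylpropyl replaces vinyl, whereas the shorter ketone chain of compound 2 moved the number the other way. Compound 2 and compound 3 both carry a ketone, so a ketone alone does not decide the outcome: lengthening the chain, with 2-acetylethyl in place of acetyl, brings a 58-fold lower number from compound 2 to compound 3 (1.77 log units; beyond the scatter) and reverses the direction of the step from compound 1. No measurement at hand explains this difference.

Going by these compounds, whether the number keeps falling with a still longer ketone chain or has already reached its lowest point remains open. Also open, on these data alone, is whether the carbonyl is needed at all, a question that a plain alkyl chain of the same length or an alcohol in place of the ketone could address.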